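The source may report more compounds than this note shows. Statements on the series, on what has been measured and on what is new or still open speak of the compounds shown alone.

Measured in an ADME assay (liver) for pharmacokinetics, with Liver microsome (Rattus norvegicus) as the target, read by LC-MS, using microsomes, tested at 2 uM; a higher number here means faster removal of the compound, a lower number slower removal:
- compound 1 `O=C(N[C@@H]1CCCC[C@H]1O)c1cnc(OC2CCC2)c(-c2ccc(Cl)cc2)c1`: 0.21 mL/min/kg
- compound 2 `O=C(N[C@@H]1CCCC[C@H]1O)c1cnc(OCC2CC2)c(-c2ccc(Cl)cc2)c1`: 0.064 mL/min/kg
- compound 3 `Cc1cc(COc2ncc(C(=O)N[C@@H]3CCCC[C@H]3O)cc2-c2ccc(Cl)cc2)on1`: 0.151 mL/min/kg

Compound 2 has the lowest number of the three. The gaps to the other two are modest but real: a 3.3-fold lower number from compound 1 to compound 2 (0.52 log units; beyond the scatter) and a 2.4-fold higher number from compound 2 to compound 3 (0.37 log units; beyond the scatter). The remaining pair sits closer together, with a 1.4-fold lower number from compound 1 to compound 3 (0.14 log units; within the scatter).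

The next compound to be measured is compound 4 `O=C(N[C@H]1CCCC[C@H]1O)c1cnc(OCC2CC2)c(-c2ccc(Cl)cc2)c1`. Here (the two compounds have the same atoms and bonds and differ only in configuration as drawn: 1 of 2 stereo elements differ; a stereocentre at a saturated ring carbon is drawn R in compound 2 and S in compound 4). In other words, nothing leaves and nothing enters, and only the configuration as drawn is different.

Going by the values given here, none of the measured steps tests such a change. All three swap the group on an oxygen on an aromatic ring, so they show only how far the numbers have moved in this small set, and they give no direction for a change of configuration. Among the compounds with values here, with no direct precedent, a small step is the most reasonable expectation. Within the data shown here, since compound 2 gives 0.064 mL/min/kg, the lowest number so far, any drift is expected to be slightly upward. The expected step is a 1.4-fold higher number from compound 2 to compound 4 (0.15 log units; within the scatter). The estimate for compound 4 is 0.09 mL/min/kg, with an expected range from 0.035 mL/min/kg to 0.25 mL/min/kg.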

Compound 4, clearance: 0.111 mL/min/kg
Compound 4: the middle estimate sits 1.2-fold (0.09 log units) below what was measured; the measured number falls inside the stated range.
By their numbers in this assay, from the lowest: compounds 2, 4, 3 and 1 (each within the scatter of the next, the first and the last beyond it).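

In this assay the change of configuration gives a 1.7-fold higher number from compound 2 to compound 4 (0.24 log units; within the scatter) and so stays inside what repeated measurements of a single compound would show. Going by these compounds alone, the earlier steps all swapped the group on an oxygen on an aromatic ring, whereas this is the first test of configuration in the set, and with cyclopropylmethyl on that oxygen, turning this stereocentre at a saturated ring carbon from R to S leaves no difference that can be told from the scatter. The comparison is a clean one because a single thing separates the pair: the fact that compounds 2 and 4 differ only in the configuration as drawn.

On these data alone, only one of the two stereo elements changes here, so it remains open what inverting the other one, or both together, would do, and whether this inversion would stay as small with cyclobutyl or (3-methyl-1,2-oxazol-5-yl)methyl on the oxygen. Also open, as far as these compounds go, is how the number would respond to an amine or a methoxy group in place of the hydroxyl group, which stays the same in all four compounds.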